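Adding a Cyanoamino Group to Compound 3

A few compounds are considered here, and "the series" means these few. Any claim that something is new, unique, unknown or untested is made for them only; others in the source may bear on it.

Compound 1 `Cc1ncc(C)c(-c2ccccc2)n1`: 12%
Compound 2 `Cc1cncnc1-c1ccccc1`: 48%
Compound 3 `c1cc(-c2ccncn2)ccn1`: 45%

In a functional assay on the whole organism for inhibition, with Rattus norvegicus as the target, with stated times of 1 h and 3.5 h, at a dose of 100 mg/kg by the oral route (on this read-out lower numbers stand for less inhibition and higher numbers for more inhibition at the one dose given (going by the name of the read-out)), compound 3 gives 45%, the second highest of the three numbers. Compound 2 gives 48%, which lies within the scatter of compound 3. Compound 1 gives 12%, lower than compound 3 by more than the scatter. Compound 4 `N#CNc1nccc(-c2ccncc2)n1` differs from compound 3 by cyanoamino in place of hydrogen on an aromatic carbon. Within the data shown here, the only measured step, a number 36 percentage points higher from compound 1 to compound 2 (beyond the scatter), concerns a methyl swapped for hydrogen and says nothing about a cyanoamino group entering, so no measured step bears directly on this change. Compound 4 is therefore expected to move little, a step of no change at the digits printed from compound 3 to compound 4 (within the scatter) with wide uncertainty. Compound 4 is estimated at 45%, somewhere between 20% and 70%.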

Compound 4, a percentage reported as inhibition, in the whole organism at one dose (the size of the read-out at that dose, not a potency): < 5%
Compound 4: no number, only a limit; the forecaster's own chance of this, stated with the estimate: 0%; middle value at least 40 percentage points from the limit.
By their numbers in this assay, from the lowest: compound 1; then compounds 3 and 2 (each within the scatter of the next). At a limit, below all of these: compound 4.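

With cyanoamino in place of hydrogen on the aromatic carbon between two ring nitrogen atoms, this assay shows a number at least 40 percentage points lower from compound 3 to compound 4 (beyond the scatter). The value of compound 4 is a limit of the assay, not a number: the limit of < 5% in this assay, at which 1 of the 4 values shown sits.

The same place holds methyl in compound 1 and hydrogen in compound 2, with a number 36 percentage points higher from compound 1 to compound 2 (beyond the scatter), so in both of these pairs a group there goes with less inhibition than hydrogen.

The compounds shown leave open whether a plain amine or a methoxy group at this place would go the same way. They also leave open whether cyanoamino would do so on the core of compound 2.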